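This account rests on a few compounds, and the source may have more. Where it says the series, first, only, none or still open, it means among the compounds named here.

Measured so far:
compound 1, `Nc1ccccc1NC(=O)c1ccc(CSC(=S)N2CCN(c3ccc(F)cc3)CC2)cc1`: 18.8%
compound 2, `Nc1ccccc1NC(=O)c1ccc(CSC(=S)N(Cc2ccccc2)Cc2ccccc2)cc1`: 11%

In a functional assay on MGC-803 cells (Homo sapiens) for antiproliferative activity, read by CCK-8 assay, with a stated time of 72 h, tested at 2 uM (a lower number here means a weaker effect, a higher number a stronger effect of the compound at the concentration tested), compound 1 gives 18.8%, and compound 2 gives 11%; the two numbers lie within the usual scatter of each other, so nothing separates compound 1 from compound 2 on these data. Compound 3, `CN1CCN(C(=S)SCc2ccc(C(=O)Nc3ccccc3N)cc2)CC1`, has not yet been measured. It differs from compound 1 in one place: methyl in place of 4-fluorophenyl on an amine nitrogen in a ring. Among the measured compounds shown here, no measured pair shows the effect of such a change, so only a small step is expected, with no clear direction beyond the scatter. The step from compound 1 to compound 3 is estimated at a number 4.8 percentage points lower from compound 1 to compound 3 (within the scatter). Compound 3 is expected to give about 14%, within a range from 4% to 26%.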

Compound 3, a percentage reported as inhibition, at one concentration (the size of the read-out at that concentration, not a potency): 29.6%
Beside the measured number, compound 3's estimate is 15.6 percentage points below it; measured number outside the range, above it.
By their numbers in this assay, from the lowest: compounds 2 and 1 (each within the scatter of the next); then compound 3.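

Replacing 4-fluorophenyl with methyl on the amine nitrogen in the ring gives the first step seen at this position in this assay: a number 10.8 percentage points higher from compound 1 to compound 3 (beyond the scatter), a modest step. The group on this nitrogen therefore does affect the read-out, and the aromatic ring is not needed there for activity at this level. No measurement here explains the change.

A single step cannot separate the loss of the fluorine from the loss of the whole ring. A plain phenyl or an ethyl on this nitrogen would help to tell these apart.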